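The source may report more compounds than this note shows. Statements on the series, on what has been measured and on what is new or still open speak of the compounds shown alone.

Measured so far:
Compound 1 `C=C[C@@](C)(/C=C/c1ccc(O)cc1)CCCO`: > 43400 nM (a limit)
Compound 2 `C=C[C@@](C)(/C=C/c1ccc(O)cc1)CC/C=C/C(=O)OCc1ccccc1`: > 43400 nM (a limit)
Compound 3 `C=C[C@@](C)(/C=C/c1ccc(O)c(C=O)c1)CCC=C(C)C`: 11200 nM (a number)

For the measured compounds named here, in a functional assay on NALM-6 cells (Homo sapiens) for cytotoxicity, with a stated time of 72 h (on this read-out higher numbers stand for an effect only at larger amounts of compound and lower numbers for an effect already at smaller amounts), compound 3 gives 11200 nM as the only true number. Compound 1 reads > 43400 nM and this is a limit of the assay. Compound 2 reads > 43400 nM and this too is a limit.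

The next compound to be tested is compound 4 `C=C[C@@](C)(/C=C/c1ccc(O)c(/C=C/C(N)=O)c1)CCC=C(C)C`, which carries 2-carbamoylethenyl in place of formyl on an aromatic carbon, ortho to a hydroxy group (2-carbamoylethenyl in place of formyl on an aromatic carbon). The rest of the structure of compound 3 is kept.

Going by the values given here, no pair of measured compounds differs in one place only, so the series offers no direct precedent for the size of this change in this assay. The expectation therefore starts from compound 3 at 11200 nM and favours no direction, with no step beyond the usual scatter. The estimated 1.3-fold higher number from compound 3 to compound 4 (0.10 log units; within the scatter) fits that view. Given the limit of > 43400 nM in this assay, at which 2 of the 3 values shown sit, as the only other reference, an outcome without a number also remains possible for compound 4. For compound 4 the expected value is 14000 nM, with an estimated range from 5000 nM to 40000 nM in this read-out.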

Compound 4, half-maximal effective concentration: > 43400 nM
Compound 4: no number, only a limit; the forecaster's own chance of this, stated with the estimate: 25%; middle value at least 3.1-fold (0.49 log units) from the limit.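

In this assay, for the compounds shown here, the aromatic carbon ortho to a hydroxy group is the first place where a single change can be read: 2-carbamoylethenyl in place of formyl gives an at least 3.8-fold higher number from compound 3 to compound 4 (0.58 log units; beyond the scatter). Compound 4 gives > 43400 nM, which is a limit of the assay and not a number. Formyl is thus the only group shown at this position that keeps a number on this read-out, and the series now rests on a single measured compound, with the others at one shared limit: the limit of > 43400 nM in this assay, at which 3 of the 4 values shown sit.

Compounds 1 and 2 differ from compound 3 in more than one place, so the compounds shown give no reading of what formyl contributes against a plain aromatic hydrogen at this position. Also open, from the compounds shown here alone, is whether the step follows the amide or the added length of 2-carbamoylethenyl, and what a carboxylic acid, an aminomethyl group or a hydroxymethyl group would give on the same carbon with the rest of compound 3 kept.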